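From fluoro to chloro: what compound 4 may show

The compounds below may be only part of what the source reports. "The series", "measured", "known", "first", "only" and "open" are said of these compounds alone.

In a functional assay on PC-3 cells (Homo sapiens) for antiproliferative activity, read by sulforhodamine B assay, with a stated time of 48 h (on this read-out higher numbers stand for weaker inhibition of growth and lower numbers for stronger inhibition of growth), compound 1 (`O=C(/C=C/c1cccc(S(=O)(=O)c2ccc3ccccc3n2)c1)NO`) gives 150 nM and compound 2 (`O=C(/C=C/c1ccc(S(=O)(=O)c2ccc3ccccc3n2)cc1)NO`) gives 490 nM as its reading. Compound 3 (`O=C(/C=C/c1cccc(S(=O)(=O)c2ccc3cccc(F)c3n2)c1)NO`) stands at 320 nM on the same read-out, which lies within the scatter of compound 2 and higher than compound 1 by more than the scatter.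

Compound 4 (`O=C(/C=C/c1cccc(S(=O)(=O)c2ccc3cccc(Cl)c3n2)c1)NO`) differs from compound 3 in a single place, with chloro in place of fluoro on an aromatic carbon. Among the compounds with values here, one measured step bears on this carbon: fluoro in place of hydrogen gave a 2.1-fold higher number from compound 1 to compound 3 (0.33 log units; beyond the scatter) as a modest change. Within the data shown here, no measured compound carries chloro, so that step is only a rough guide to size and gives no firm direction for the new swap. The expectation in this assay is therefore for no step beyond the scatter, though a modest move either way remains possible. The expected change is a 1.1-fold higher number from compound 3 to compound 4 (0.04 log units; within the scatter) in size, and it is estimated to stay within the scatter. For compound 4 the estimated value is 350 nM with a range from 160 nM to 760 nM expected to cover most repeat measurements.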

Compound 4, concentration for 50% growth inhibition: 1350 nM
For compound 4 the middle estimate is 3.9-fold (0.59 log units) below the measured one, and the stated range ends below it.
By their numbers in this assay, from the lowest: compound 1; then compounds 3 and 2 (each within the scatter of the next); then compound 4.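

In this assay this aromatic carbon proves sensitive to which halogen it carries: chloro in place of fluoro gives a 4.2-fold higher number from compound 3 to compound 4 (0.63 log units; beyond the scatter) and so does not behave as an equivalent of fluoro here. Within the data shown here, the earlier compounds showed only the step from hydrogen to fluoro, a 2.1-fold higher number from compound 1 to compound 3 (0.33 log units; beyond the scatter), while the step from hydrogen to chloro is a 9.0-fold higher number from compound 1 to compound 4 (0.95 log units; beyond the scatter) and shows that both halogens on this carbon give higher numbers than hydrogen, each by more than the scatter, with chloro giving the highest number of the three. The data shown offer no explanation for the step from fluoro to chloro.

The compounds shown leave open whether the number would rise further with bromo on this same carbon, or whether a methoxy group or an amine there would bring it back towards that of compound 1 at 150 nM in this assay. Also open, on these data alone, is whether chloro on this carbon would give a step of similar size on the otherwise different arrangement of compound 2.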